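The source may report more compounds than this note shows. Statements on the series, on what has been measured and on what is new or still open speak of the compounds shown alone.

Measured so far in a functional assay on the whole organism (strain albino) for inhibition, with Rattus norvegicus as the target, read by paw edema, with a stated time of 1 h, at a dose of 20 mmol/kg by the intraperitoneal route; on this read-out higher numbers stand for more inhibition at the one dose given (going by the name of the read-out) and lower numbers for less inhibition:

compound 1 `N#CC1=C(NCN2CCCC2)N(c2ccccc2)C(=O)N2CCCCC(N3CCCC3)C12`: 22.9%
compound 2 `N#CC1=C(/N=C/Nc2ccc([N+](=O)[O-])cc2)N(c2ccccc2)C(=O)N2CCCCC(N3CCCC3)C12`: 32.1%
compound 3 `CCOC(=O)C(=O)NC1=C(C#N)C2C(N3CCCC3)CCCCN2C(=O)N1c1ccccc1`: 71.2%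

Compound 2 stands second highest of the three; its gap to compound 1, a number 9.2 percentage points higher from compound 1 to compound 2 (within the scatter), is within the scatter, while a number 39.1 percentage points higher from compound 2 to compound 3 (beyond the scatter) is beyond it.

Compound 4 `N#CC1=C(NC(=O)c2ccccc2O)N(c2ccccc2)C(=O)N2CCCCC(N3CCCC3)C12` is unmeasured. Change from compound 2: a group of 10 heavy atoms (7 carbon, 1 nitrogen, 2 oxygen; one six-membered aromatic ring of carbon only) in place of a group of 12 heavy atoms (7 carbon, 3 nitrogen, 2 oxygen; one six-membered aromatic ring of carbon only), on a double-bonded ring carbon

The bearing steps are the two that replaced the group on the same double-bonded ring carbon or on the amine nitrogen: a number 39.1 percentage points higher from compound 2 to compound 3 (beyond the scatter) and a number 48.3 percentage points higher from compound 1 to compound 3 (beyond the scatter), both large and upward, both ending in compound 3, which carries a carbonyl on the amine nitrogen as compound 4 does. The entering ((2-hydroxyphenyl)carbonyl)amino is not the (ethoxycarbonyl)carbonyl of compound 3, so a smaller rise is expected. For compound 4 the estimated step is a number 19.9 percentage points higher from compound 2 to compound 4 (beyond the scatter), upward, beyond the scatter. Compound 4 is expected to give 52%, within 32% to 72%.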

Compound 4, a percentage reported as inhibition, in the whole organism at one dose (the size of the read-out at that dose, not a potency): 44.7%
The estimate for compound 4 lay 7.3 percentage points above the measured number; the measured number falls inside the stated range.
By their numbers in this assay, from the lowest: compounds 1 and 2 (each within the scatter of the next); then compound 4; then compound 3.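

At the double-bonded ring carbon, ((2-hydroxyphenyl)carbonyl)amino lifts the read-out in this assay clear of both earlier low compounds (a number 12.6 percentage points higher from compound 2 to compound 4 (beyond the scatter)) and (a number 21.8 percentage points higher from compound 1 to compound 4 (beyond the scatter)). A carbonyl on the amine nitrogen does not alone reach the level of compound 3: what the carbonyl carbon carries also matters, as 2-hydroxyphenyl in place of ethoxycarbonyl shows (a number 26.5 percentage points lower from compound 3 to compound 4 (beyond the scatter)). No measured evidence bears on these steps. Open, from the compounds shown here alone, is whether the hydroxyl counts, which plain phenyl on that carbonyl carbon would test. A carboxylic acid in place of ethoxycarbonyl would test the ester.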